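The source may hold more compounds than are shown below. What is called first, only, known or untested is meant among the compounds shown, and "the series" means these compounds.

Working notes on the enone series. Compound 1 `CCC(/C=C(\CCOC(C)=O)C(=O)c1ccc(OC)cc1)CC` carries pentan-3-yl on a double-bonded chain carbon bound to a double-bonded chain carbon, and compound 2 `COc1ccc(C(=O)/C(=C/C2CCCCC2)CCOC(C)=O)cc1` carries cyclohexyl at the same place. In a functional assay on A549 cells (Homo sapiens) for inhibition, read by XTT assay, with a stated time of 48 h (on this read-out higher numbers stand for weaker inhibition and lower numbers for stronger inhibition), compound 1 gives only a limit of the assay, > 100000 nM. In this assay compound 2 likewise gives only a limit of the assay, > 100000 nM. The step that the two limits leave unreadable from compound 1 to compound 2 is thus not readable, and the whole evidence on the measured values is the limit of > 100000 nM in this assay, at which 2 of the 2 values shown sit. Compound 2 therefore stands nowhere more precisely than at that limit.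

Compound 3 `COc1ccc(C(=O)/C(=C/c2ccc([N+](=O)[O-])cc2)CCOC(C)=O)cc1` is the next member. Compared with compound 2, (4-nitrophenyl in place of cyclohexyl on a double-bonded chain carbon bound to a double-bonded chain carbon). For the measured compounds named here, the only measured step, the one from compound 1 to compound 2, exchanges one saturated carbon substituent for another and is itself unreadable; no measured step covers an aromatic or nitro-bearing substituent at this place. The data thus give no size and no direction for the change to expect in this assay. Compound 3 is accordingly estimated at 60000 nM, within 10000 nM to 200000 nM, with a limit again the most likely report. The expected step is an at least 1.6-fold lower number from compound 2 to compound 3 (0.22 log units; that floor lies within the scatter).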

Compound 3, half-maximal inhibitory concentration: > 100000 nM
Compound 3 gave a limit, no number; the forecaster's own chance of this, stated with the estimate: 60%; at least 1.6-fold (0.22 log units) between middle value and limit.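

In this assay compound 3 also gives only a limit, > 100000 nM. No new step can be read, neither from compound 2 to compound 3 nor from compound 1 to compound 3. The compounds shown leave open whether pentan-3-yl, cyclohexyl and 4-nitrophenyl differ at all at this place, and in which direction.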